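Dithioester hexanoic acids: anilide in place of the acid

The source may report more compounds than this note shows. Statements on the series, on what has been measured and on what is new or still open speak of the compounds shown alone.

Four compounds share a dithioester-substituted chain ending in a carbonyl; they fall into two pairs with different cores. Compound 1 `CC(=O)SCCC(CCCCC(=O)O)SC(C)=O` carries the acid; compound 3 `CC(=O)SCCC(CCCCC(=O)Nc1ccccc1)SC(C)=O` is its anilide, differing by anilino in place of hydroxy on a carbonyl carbon. Compound 2 `O=C(O)CCCCC(CCSC(=O)c1ccccc1)SC(=O)c1ccccc1` is the acid of the second core and compound 4 `O=C(CCCCC(CCSC(=O)c1ccccc1)SC(=O)c1ccccc1)Nc1ccccc1` its anilide, differing by anilino in place of hydroxy on a carbonyl carbon. How the core of compound 1 and the core of compound 2 differ from each other is not broken down here.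

In a functional assay on Bel-7402 cells (Homo sapiens) for inhibition, read by MTT assay, with a stated time of 24 h, tested at 1 ug/mL (a higher number here means more inhibition of growth at the concentration tested, a lower number less inhibition of growth), compound 1 gives 12.8% and compound 3 gives 2.84%; the step of a number 10 percentage points lower from compound 1 to compound 3 (within the scatter). For the measured compounds named here, compound 2 was recorded in this assay as "not active" (no number reported), so no number is available for it, and no step from compound 2 to compound 4 can be computed.

The change from compound 2 to compound 4 is the same change as from compound 1 to compound 3: the "place:" lines read the same word for word. The expectation for compound 4 therefore rests on two points: the anilide of the first core stayed within the scatter of its acid, shown by compound 3 at 2.84%, and the acid of the second core, compound 2, was recorded as "not active" (no number reported). Nothing in the series points to a gain in growth inhibition on going to the anilide. Compound 4 is expected to give 3% in this assay, estimated between -8% and 14%, with a fair chance that it is again reported only as inactive without a number.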

Compound 4, percent growth inhibition at one concentration: "not active" (no number reported)
For compound 4 the study gives words and no number, so the estimate cannot be set against anything.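

For the compounds shown here, compound 2 and compound 4 are both recorded as not active without a number in this assay so no step between them can be read. The compounds shown leave open whether anilino in place of hydroxy on a carbonyl carbon alters growth inhibition on the core of compound 2. No measurement shown offers an explanation for this result.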